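A Methyl Swapped for Trifluoromethyl

The source may report more compounds than this note shows. Statements on the series, on what has been measured and on what is new or still open speak of the compounds shown alone.

Compound 1 `COc1ccc(/C=C2/CN(C)/C(=N/c3ccc(C)cc3)S2)cc1`: 11100 nM
Compound 2 `C=C1CN(C)/C(=N/c2ccccc2)S1`: > 100000 nM

Going by the values given here, in a functional assay on HCT-116 cells (Homo sapiens) for antiproliferative activity, read by MTT assay, with a stated time of 72 h (a higher number here means a weaker inhibitor, a lower number a stronger inhibitor), compound 1 gives 11100 nM, the only true number available so far. Compound 2 reads > 100000 nM, which is a limit of the assay and not a number.

Compound 3 `COc1ccc(/C=C2/CN(C)/C(=N/c3ccc(C(F)(F)F)cc3)S2)cc1` keeps the core of compound 1 and differs in one place: trifluoromethyl in place of methyl on an aromatic carbon. Among the compounds with values here, no measured pair shows what this swap does, so compound 1 at 11100 nM is the sole anchor for a prediction. In this assay, no change beyond the usual scatter is expected in either direction. The expected step is a 1.2-fold lower number from compound 1 to compound 3 (0.09 log units; within the scatter). For compound 3 the estimated value is 9000 nM, with an expected range from 2500 nM to 35000 nM.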

Compound 3, half-maximal inhibitory concentration: 34300 nM
For compound 3 the middle estimate is 3.8-fold (0.58 log units) below the measured one; measured number inside the range.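

In this assay, this position on the aromatic ring, para to a large group, proves not to be indifferent to what sits on it: the swap gives a 3.1-fold higher number from compound 1 to compound 3 (0.49 log units; beyond the scatter). So replacing methyl with trifluoromethyl, which brings more heavy atoms, weakens the compound here rather than strengthening it, though the step is modest and rests on this single pair. Compound 3 also still gives a true number, so the swap does not push the compound to the limit of the assay.

Why the number rises cannot be told from this pair, and whether an amine or a chlorine atom at this position would land nearer compound 1 or compound 3 stays open. Compound 2 gives only a limit of the assay, not a number, and no step to it can be read: the limit of > 100000 nM in this assay, at which 1 of the 3 values shown sits.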